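The compounds below may be only part of what the source reports. "The series", "measured", "known", "first", "only" and "open" are said of these compounds alone.

Compound 1, `Cc1c(C(=O)NCc2cccc(C(F)(F)F)c2)cnn1-c1ccccc1Cl`, in a functional assay on cells for antagonist activity at C-C chemokine receptor type 1 (Homo sapiens), read by FLIPR and calcium flux (a lower number here means a stronger inhibitor, a higher number a weaker inhibitor), gives only a limit, > 3000 nM.
Compound 2, `Cc1cccc(-n2ncc(C(=O)NCc3cccc(C(F)(F)F)c3)c2C)c1`, in this assay gives only a limit, > 3000 nM.
Compound 3, `Cc1c(C(=O)NCc2cccc(C(F)(F)F)c2)cnn1-c1cccc(C(F)(F)F)c1`, in this assay gives only a limit, > 3000 nM.

Compound 3 therefore stands nowhere in particular on the numbers shown: its value is a limit, and the two other values shown are limits as well, so that all three sit together at the limit of > 3000 nM in this assay, at which 3 of the 3 values shown sit. The steps a step that the two limits leave unreadable from compound 1 to compound 3 and a step that the two limits leave unreadable from compound 2 to compound 3 are for this reason not readable in size, and the same holds for a step that the two limits leave unreadable from compound 1 to compound 2.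

Compound 4 is `Cc1c(C(=O)NCc2cccc(C(F)(F)F)c2)cnn1-c1ccc([N+](=O)[O-])cc1`. Its change from compound 3 is 4-nitrophenyl in place of 3-(trifluoromethyl)phenyl on an aromatic nitrogen. The measured steps that bear on it are the two that end at compound 3, from compound 1 and from compound 2, and both are unreadable, since each of the three phenyl variants on that ring nitrogen sits at the limit. Going by the values given here, no measured step thus gives a direction or a size for the change to compound 4 in this assay. The estimate for compound 4 is accordingly 5000 nM, with a range from 1500 nM to 20000 nM. The expected step that the limit leaves unreadable from compound 3 to compound 4 is correspondingly one that leaves compound 4 at or near the limit, with a fair chance that this assay again reports only a limit for compound 4.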

Compound 4, half-maximal inhibitory concentration: 960 nM
The estimate for compound 4 lay 5.2-fold (0.72 log units) above the measured number, and the stated range ends above it.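

Going by these compounds alone, the aromatic nitrogen of the shared core had so far yielded only unreadable steps, but compound 4 shows that the group held there can change the result in this assay. The change to 4-nitrophenyl gives an at least 3.1-fold lower number from compound 3 to compound 4 (0.49 log units; beyond the scatter), an at least 3.1-fold lower number from compound 2 to compound 4 (0.49 log units; beyond the scatter) and an at least 3.1-fold lower number from compound 1 to compound 4 (0.49 log units; beyond the scatter); each of these sizes is only a bound, since each starting compound stands at a limit. Among the four compounds, 4-nitrophenyl is the only group on this nitrogen that brings a compound off the limit in this assay, while 3-(trifluoromethyl)phenyl, 3-methylphenyl and 2-chlorophenyl all stay there: the limit of > 3000 nM in this assay, at which 3 of the 4 values shown sit.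

The steps among compound 1, compound 2 and compound 3 remain unreadable, so no order can be given for those three groups, and compound 4 alone cannot tell whether the change belongs to the nitro group or to the place it holds on the phenyl ring. From the compounds shown here alone, it also remains open whether a nitrile, an amine or a carboxylic acid in that same place on the phenyl ring would give a number in this assay or stay at the limit.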